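From Ethoxycarbonyl to Methoxycarbonyl on a Shared Core

The compounds below may be only part of what the source reports. "The series", "measured", "known", "first", "only" and "open" are said of these compounds alone.

Of the compounds shown here, three built on one shared core have been measured in an assay on isolated protein for inhibition of Rho-associated protein kinase 2 (Homo sapiens), read by radiometric assay; on this read-out higher numbers stand for weaker inhibition and lower numbers for stronger inhibition. Compound 1 `CCCCOC(=O)c1cccc(-c2cc(C(=O)Nc3ccncc3)ccc2CN)c1` gives 5.5 nM, and compound 2 `CCCCCOC(=O)c1cccc(-c2cc(C(=O)Nc3ccncc3)ccc2CN)c1` gives 4.9 nM; the step of a 1.1-fold lower number from compound 1 to compound 2 (0.05 log units; within the scatter) lies within the scatter. Compound 3 `CCOC(=O)c1cccc(-c2cc(C(=O)Nc3ccncc3)ccc2CN)c1` gives < 1 nM, which is a limit of the assay and not a number. Compound 3 thus stands at the limit of < 1 nM in this assay, at which 1 of the 3 values shown sits, so its value is known only as a limit. Cutting the chain back toward compound 3 gave an at least 5.5-fold lower number from compound 1 to compound 3 (0.74 log units; beyond the scatter) and an at least 4.9-fold lower number from compound 2 to compound 3 (0.69 log units; beyond the scatter), both beyond the scatter and both toward stronger inhibition.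

Compound 4 `COC(=O)c1cccc(-c2cc(C(=O)Nc3ccncc3)ccc2CN)c1` continues in the same direction by one further cut: hydrogen in place of methyl on a saturated chain carbon bound to an oxygen next to a carbonyl group. The two steps that end in compound 3 are the ones that bear on it, and each trimmed the chain while lowering the number beyond the scatter. A further trimming is therefore expected to leave the number at or below the limit already reached, so the step that the limit leaves unreadable from compound 3 to compound 4 is expected to be small or downward, though it starts from a limit and is uncertain. Compound 4 is accordingly estimated at 0.7 nM, within 0.2 nM to 3 nM, with a fair chance that the assay again reports only a limit.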

Compound 4, half-maximal inhibitory concentration: 2.9 nM
Compound 4: middle estimate off by 4.1-fold (0.62 log units), on the low side, within the range that was stated.
By their numbers in this assay, from the lowest: compounds 4, 2 and 1 (each within the scatter of the next). At a limit, below all of these: compound 3.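

Going from ethoxycarbonyl to methoxycarbonyl gave an at least 2.9-fold higher number from compound 3 to compound 4 (0.46 log units; beyond the scatter), so in this assay the shortening of the chain that had lowered the number in the earlier steps does not carry on to the shortest group, and the direction reverses at this position. For the compounds shown here, compound 4 also sits with the longer chains and does not separate from them, with a 1.7-fold lower number from compound 2 to compound 4 (0.23 log units; within the scatter) and a 1.9-fold lower number from compound 1 to compound 4 (0.28 log units; within the scatter), which leaves compound 3 alone as the one member set apart from the other three. Adding or removing one carbon therefore need not count the same at every chain length, although the comparison remains unsettled: the same change on two cores in this assay, a 1.1-fold lower number (0.05 log units; within the scatter) from compound 1 to compound 2 and an at least 2.9-fold lower number (0.46 log units; beyond the scatter) from compound 4 to compound 3; the limit leaves it open whether they differ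

As far as these compounds go, the value of compound 3, < 1 nM, is a limit and not a number, so how far it truly lies from the others stays open. Also open, from the compounds shown here alone, is whether the low number belongs to ethoxycarbonyl alone, and how a branched chain, a carboxylic acid or an amide at this place would read in this assay.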